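Heteroaryl swap at the aromatic carbon: note on compound 3

The compounds below may be only part of what the source reports. "The series", "measured", "known", "first", "only" and "open" are said of these compounds alone.

Measured so far in a functional assay for activation of Alpha-1A adrenergic receptor (Homo sapiens), read by calcium flux; on this read-out lower numbers stand for an effect already at smaller amounts and higher numbers for an effect only at larger amounts of compound:
- compound 1 `c1cncc(-c2ccccc2OCC2=NCCN2)c1`: 2 nM
- compound 2 `c1ccc(-c2cc[nH]n2)c(OCC2=NCCN2)c1`: 5.01 nM

Compound 2 stands highest of the two numbers in this assay; its nearest neighbour is compound 1, with a 2.5-fold higher number from compound 1 to compound 2 (0.40 log units; beyond the scatter). Compound 3 `Cc1cc(-c2ccccc2OCC2=NCCN2)sn1` differs from compound 2 by 3-methyl-1,2-thiazol-5-yl in place of 1H-pyrazol-3-yl on an aromatic carbon. Within the data shown here, the only step that bears on this change is the one from compound 1 to compound 2, where exchanging the aromatic group at the same carbon gave a modest shift. A step of comparable size is expected for a 1.2-fold higher number from compound 2 to compound 3 (0.08 log units; within the scatter), with direction uncertain, most likely not beyond the scatter. Compound 3 is therefore estimated at 6 nM, within 2 nM to 20 nM.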

Compound 3, half-maximal effective concentration: 158 nM
For compound 3 the middle estimate is 26-fold (1.42 log units) below the measured one, outside the stated range (above it).
By their numbers in this assay, from the lowest: compound 1; then compound 2; then compound 3.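

In this assay, this aromatic carbon proves far less forgiving than the first exchange suggested: 3-methyl-1,2-thiazol-5-yl gives a 32-fold higher number from compound 2 to compound 3 (1.50 log units; beyond the scatter) and a 79-fold higher number from compound 1 to compound 3 (1.90 log units; beyond the scatter), both large beside the modest earlier step. This change replaces a ring carrying a hydrogen-bond donor with one carrying none and also brings in sulfur and a methyl, so several differences travel together. Nothing available indicates which of them accounts for the higher number.

Going by these compounds, it remains open whether the methyl or the ring itself matters; the unsubstituted 1,2-thiazol-5-yl would separate the two.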